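Chlorine additions on the benzyl triazole series

The source may hold more compounds than are shown below. What is called first, only, known or untested is meant among the compounds shown, and "the series" means these compounds.

Compound 2 `O=c1ccoc2cc(OCc3cn(Cc4ccc(Cl)cc4)nn3)ccc12` carries a 4-chlorobenzyl group on the shared core. In a functional assay on A549 cells (Homo sapiens) for cytotoxicity, read by MTT assay, with a stated time of 48 h (on this read-out higher numbers stand for weaker inhibition and lower numbers for stronger inhibition), compound 2 gives only a limit, > 100000 nM. Compound 1 `O=c1ccoc2cc(OCc3cn(Cc4ccccc4)nn3)ccc12` likewise gives only a limit in this assay, > 100000 nM. The step that the two limits leave unreadable from compound 1 to compound 2 therefore has no readable size; both values sit at the limit of > 100000 nM in this assay, at which 2 of the 2 values shown sit. Compound 3 `O=c1ccoc2cc(OCc3cn(Cc4ccc(Cl)cc4Cl)nn3)ccc12` differs from compound 2 by chloro in place of hydrogen on an aromatic carbon. Going by the values given here, no measured step bearing on this change is readable, so no direction beyond the scatter is indicated. Compound 3 is expected to stay at the limit, estimated at 100000 nM with a range from 30000 nM to 300000 nM. The expected step is a number no higher from compound 2 to compound 3 (the limit leaves the size open).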

Compound 3, half-maximal inhibitory concentration: 5260 nM
Beside the measured number, compound 3's estimate is 19-fold (1.28 log units) above it; the measured number lies below the stated range.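

The added chloro group, ortho to a large group and meta to a chloro group, brings a readable value into the series: in this assay the change gives an at least 19-fold lower number from compound 2 to compound 3 (1.27 log units; beyond the scatter). The 2,4-dichlorophenyl in place of phenyl likewise gives an at least 19-fold lower number from compound 1 to compound 3 (1.27 log units; beyond the scatter). The step to the 4-chlorobenzyl group of compound 2 could not be read, and the true size of both new steps stays open, since compound 1 and compound 2 sit at a limit: the limit of > 100000 nM in this assay, at which 2 of the 3 values shown sit.

From the compounds shown here alone, whether a single chloro group ortho to a large group gives such a value without the second chloro group stays open. Also open, going by these compounds, is whether a methoxy group or an amine on that carbon would give a similar number.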